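The compounds below may be only part of what the source reports. "The series", "measured", "known", "first", "only" and "open" are said of these compounds alone.

Compound 2 `Nc1scc(CN2CCN(c3cccc(F)c3F)CC2)c1C(=O)c1ccc(Cl)cc1` stands at -79% in a functional assay on CHO cells with adenosine receptor A1 (Homo sapiens) as the target, read by cAMP accumulation and immunoassay, with a stated time of 6 min, tested at 10 uM (a lower number here means a stronger effect, a higher number a weaker effect of the compound at the concentration tested), the lowest of the two numbers measured; compound 1 `CC(C)N1CCN(Cc2csc(N)c2C(=O)c2ccc(Cl)cc2)CC1` gives -7.4% in this assay. Going by the values given here, the one measured step, a number 71.6 percentage points lower from compound 1 to compound 2 (beyond the scatter), is large. Compound 3 `Nc1scc(CN2CCN(c3ccccc3Cl)CC2)c1C(=O)c1ccc(Cl)cc1` differs from compound 2 by 2-chlorophenyl in place of 2,3-difluorophenyl on an amine nitrogen in a ring. Among the compounds with values here, no measured step sets one aryl group against another on that ring nitrogen, so the large step between compound 1 and compound 2 bears only loosely on this change, and he expects a step within or just beyond the scatter. For compound 3 the estimate in this assay is -70%, ranging from -90% to -40%, which is expected to mean a step of a number 9 percentage points higher from compound 2 to compound 3 (within the scatter).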

Compound 3, a percentage reported as activity, at one concentration (the size of the read-out at that concentration, not a potency): -18%
The estimate for compound 3 lay 52 percentage points below the measured number; measured number outside the range, above it.
By their numbers in this assay, from the lowest: compound 2; then compound 3; then compound 1.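

On the ring nitrogen in this assay, the aryl groups are not interchangeable: 2-chlorophenyl in place of 2,3-difluorophenyl gives a large step, a number 61 percentage points higher from compound 2 to compound 3 (beyond the scatter) in this series. An aryl group alone therefore does not carry the low number, as the step for 2-chlorophenyl in place of isopropyl, a number 10.6 percentage points lower from compound 1 to compound 3 (beyond the scatter) here, is only modest. Nothing measured accounts for this difference between the two aryl groups. The two groups differ in both the halogen and the number of halogen atoms, and the compounds shown do not separate these. Where a plain phenyl or a 2-fluorophenyl group on that nitrogen would fall remains open.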